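Working notes: from compound 3 to compound 4

A few compounds are considered here, and "the series" means these few. Any claim that something is new, unique, unknown or untested is made for them only; others in the source may bear on it.

Three compounds of the shared core have numbers in a functional assay on CHO cells for inhibition of metabotropic glutamate receptor 5 (Rattus norvegicus), read by FLIPR and calcium flux; on this read-out lower numbers stand for stronger inhibition and higher numbers for weaker inhibition. Compound 1 `Cc1ccc2ccc(-c3cccnc3)cc2n1` gives 510 nM, compound 2 `COc1cccc(-c2ccc3ccc(C)nc3c2)c1` gives 860 nM, and compound 3 `Cc1ccc2ccc(-c3cccc(CO)c3)cc2n1` gives 8700 nM. Compound 3 stands highest of the three; its nearest neighbour is compound 2, and compound 1 lies furthest from it. Among the compounds with values here, the only step measured between compounds differing in a single place is a 10-fold higher number from compound 2 to compound 3 (1.01 log units; beyond the scatter), a large move for the exchange of one group on the same aromatic carbon.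

Compound 4 `Cc1ccc2ccc(-c3cccc(C(F)(F)F)c3)cc2n1` is not yet measured in this assay. The change from compound 3 is trifluoromethyl in place of hydroxymethyl on an aromatic carbon. Within the data shown here, no measured step covers this exact swap. Among the measured compounds shown here, the step bearing on it is the one from compound 2 to compound 3, which shows that exchanging the group at this carbon shifts the number strongly. The group that leaves compound 3 is the one whose arrival produced a 10-fold higher number from compound 2 to compound 3 (1.01 log units; beyond the scatter). A number nearer to that of compound 2 is therefore expected for compound 4, a step of an 8.7-fold lower number from compound 3 to compound 4 (0.94 log units; beyond the scatter). Compound 4 is estimated at 1000 nM, within 300 nM to 4000 nM.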

Compound 4, half-maximal inhibitory concentration: > 10000 nM
Compound 4: a limit, no number; the forecaster's own chance of this, stated with the estimate: 5%; middle value at least 10-fold (1.00 log units) from the limit.
By their numbers in this assay, from the lowest: compounds 1 and 2 (each within the scatter of the next); then compound 3. At a limit, above all of these: compound 4.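

Compound 4 gives no number in this assay, only a limit: the limit of > 10000 nM in this assay, at which 1 of the 4 values shown sits. Against the methoxy of compound 2, the change reads as an at least 11-fold higher number from compound 2 to compound 4 (1.06 log units; beyond the scatter), so trifluoromethyl at this aromatic carbon does not bring back the number of compound 2. Against compound 3, it reads only as an at least 1.1-fold higher number from compound 3 to compound 4 (0.06 log units; that floor lies within the scatter), so hydroxymethyl is no longer the only group shown to give a large step away from methoxy at this carbon, and the high number of compound 3 is not specific to hydroxymethyl.

The limit leaves open how far compound 4 lies from compound 3, and therefore whether trifluoromethyl and hydroxymethyl differ here at all. Also open, going by these compounds, is whether a nitrile, an amine or an ethoxy group on this carbon would stay close to compound 2.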